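The compounds below may be only part of what the source reports. "The series", "measured", "known", "first", "only" and "open" are said of these compounds alone.

Series notes. Compound 1 `COc1cc(C(=O)c2sc3ccccc3c2-c2ccccc2)cc(OC)c1OC` gives 1700 nM in a functional assay on HL-60 cells (Homo sapiens) for antiproliferative activity, read by MTT assay, with a stated time of 72 h; on this read-out higher numbers stand for weaker inhibition and lower numbers for stronger inhibition. Compound 2 `COc1cc(C(=O)c2sc3ccccc3c2-c2ccc(Cl)cc2)cc(OC)c1OC` gives 3300 nM in this assay; the step is a 1.9-fold higher number from compound 1 to compound 2 (0.29 log units; within the scatter), made by chloro in place of hydrogen on an aromatic carbon. Compound 3 `COc1cc(C(=O)c2sc3ccccc3c2Nc2ccccc2)cc(OC)c1OC` gives 5200 nM in this assay; its core differs from that of compound 1 by anilino in place of phenyl on an aromatic carbon, and the step is a 3.1-fold higher number from compound 1 to compound 3 (0.49 log units; beyond the scatter). Between the other pair the step is a 1.6-fold higher number from compound 2 to compound 3 (0.20 log units; within the scatter). Compound 4 `COc1cc(C(=O)c2sc3ccccc3c2Nc2ccc(Cl)cc2)cc(OC)c1OC` is not yet measured in this assay. It differs from compound 3 by chloro in place of hydrogen on an aromatic carbon. The place of this change reads word for word as it does between compound 1 and compound 2, so it is the same change, now on the other core. Among the compounds with values here, the expected step in this assay is a 1.7-fold higher number from compound 3 to compound 4 (0.24 log units; within the scatter), resting on the single observed instance of this change, because a 1.9-fold higher number from compound 1 to compound 2 (0.29 log units; within the scatter). Compound 4 is estimated at 9000 nM, expected between 4000 nM and 20000 nM.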

Compound 4, half-maximal inhibitory concentration: 5400 nM
Beside the measured number, compound 4's estimate is 1.7-fold (0.22 log units) above it, within the range that was stated.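

On the core of compound 3, the chloro change gives a 1.0-fold higher number from compound 3 to compound 4 (0.02 log units; within the scatter), and the two instances of this change do not differ beyond the scatter: the same change on two cores in this assay, a 1.9-fold higher number (0.29 log units; within the scatter) from compound 1 to compound 2 and a 1.0-fold higher number (0.02 log units; within the scatter) from compound 3 to compound 4, 1.9-fold (0.27 log units) apart, within the scatter of two such steps. Both steps lie within the scatter, so these two pairs show no clear effect of chloro on either core and no difference between the cores, and they cannot establish a transfer rule for the series. With chloro in both compounds of the pair, there is a 1.6-fold higher number from compound 2 to compound 4 (0.21 log units; within the scatter), while the other comparison shows a 3.2-fold higher number from compound 1 to compound 4 (0.50 log units; beyond the scatter).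

Still open, from the compounds shown here alone, is whether an amine or a carboxylic acid in place of the chloro would behave alike on both cores. Also open, going by these compounds, is whether these small steps hold outside this assay.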